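Chain length at the ring nitrogen of the shared core

A few compounds are considered here, and "the series" means these few. Any claim that something is new, unique, unknown or untested is made for them only; others in the source may bear on it.

Measured so far:
compound 1, `CCn1c(=O)n(C2OC(CO)[C@@H](O)[C@H]2O)c2nc(N)nc(O)c21`, gives 15 uM
compound 2, `C=CCn1c(=O)n(CCC(CCOCc2ccccc2)CCOCc2ccccc2)c2nc(N)nc(O)c21`, gives 7 uM
compound 3, `C=CCn1c(=O)n(C2OC(CO[Si](c3ccccc3)(c3ccccc3)C(C)(C)C)[C@@H](O)[C@H]2O)c2nc(N)nc(O)c21`, gives 18 uM

In a functional assay (B cells) with Mus musculus as the target (a lower number here means that less compound is needed, a higher number that more compound is needed for the effect), compound 1 stands second highest of the three numbers. Compound 3 lies nearest to it, within the scatter, so no order between compound 1 and compound 3 can be read from these values. Compound 2 lies furthest, with a lower number that is beyond the scatter. Among the compounds with values here, compound 2 and compound 3 are not single-point changes from compound 1, so no step is known for any one change.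

Compound 4, `CCCCn1c(=O)n(C2OC(CO)[C@@H](O)[C@H]2O)c2nc(N)nc(O)c21`, differs from compound 1 by ethyl in place of hydrogen on a saturated chain carbon, two bonds along the chain from an aromatic nitrogen. Within the data shown here, no pair of measured compounds shows this change, so its effect is an open question. Given that the three measured values sit close together in this assay, the step from compound 1 to compound 4 is expected to be small, if anything a slight lowering, and likely not beyond the scatter: a 1.4-fold lower number from compound 1 to compound 4 (0.13 log units; within the scatter). Compound 4 is therefore estimated at 11 uM, within a range of 4 uM to 30 uM.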

Compound 4, concentration for half-maximal effect: 11 uM
Compound 4: middle estimate and measured number agree at the digits printed, within the range that was stated.
By their numbers in this assay, from the lowest: compounds 2, 4, 1 and 3 (each within the scatter of the next, the first and the last beyond it).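

In this assay the series now holds its first comparison of compounds that differ in one place: a 1.4-fold lower number from compound 1 to compound 4 (0.13 log units; within the scatter) for ethyl in place of hydrogen on a saturated chain carbon, two bonds along the chain from an aromatic nitrogen. Cut one bond further out, this difference reads ethyl to butyl, and the numbers do not separate the two compounds at this position. No measurement here bears on the size of this step.

Open, from the compounds shown here alone, is whether a longer chain such as hexyl, or a chain ending in an amine or a carboxylic acid, would move the number beyond the scatter at this position. Compound 2 and compound 3 differ from compound 1 in more than one place, and what each of their differences contributes cannot be read.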